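Chloro to Isopropyl on the Shared Core: Compound 4

The compounds below may be only part of what the source reports. "The series", "measured", "known", "first", "only" and "open" are said of these compounds alone.

Of the compounds shown here, three built on one shared core have been tested in a functional assay on HepG2 cells (Homo sapiens) for cytotoxicity, read by MTT assay; on this read-out higher numbers stand for weaker inhibition and lower numbers for stronger inhibition. Compound 1 `COc1cc(OC)cc(-c2cc(=O)c3cc(Cl)ccc3o2)c1` gives 1100 nM. Compound 2 `O=c1cc(C2CCCCC2)oc2ccc(Cl)cc12` gives 20000 nM, and compound 3 `O=c1cc(C2CCCC2)oc2ccc(Cl)cc12` gives 13400 nM. Among these three numbers compound 3 stands second highest: compound 2 lies nearest to it, within the scatter, while compound 1 lies furthest away, with a much lower number that is beyond the scatter.

Among the measured compounds shown here, the only measured step between compounds that differ in a single place is a 1.5-fold lower number from compound 2 to compound 3 (0.17 log units; within the scatter), where cyclopentyl replaces cyclohexyl on an aromatic carbon; it does not touch the chloro-bearing ring.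

Compound 4 `CC(C)c1ccc2oc(C3CCCC3)cc(=O)c2c1` differs from compound 3 in one place: isopropyl in place of chloro on an aromatic carbon. For the measured compounds named here, no measured step changes this position, so the record gives no direct guide to the size or direction of the change. Lacking any such step, the most cautious expectation is that the swap leaves the number largely where it is. The step of a 1.1-fold lower number from compound 3 to compound 4 (0.05 log units; within the scatter) is therefore expected to stay within the scatter. In this assay compound 4 is expected to give about 12000 nM, with a range from 4000 nM to 40000 nM to reflect the missing precedent.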

Compound 4, half-maximal inhibitory concentration: 8600 nM
Beside the measured number, compound 4's estimate is 1.4-fold (0.14 log units) above it, and the stated range covers the measured number.
By their numbers in this assay, from the lowest: compound 1; then compounds 4, 3 and 2 (each within the scatter of the next, the first and the last beyond it).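

Among the compounds shown here, this is the first measured change at the position that carries chloro on the shared core, and in this assay replacing chloro with isopropyl gives a 1.6-fold lower number from compound 3 to compound 4 (0.19 log units; within the scatter). With cyclopentyl kept the same, a single chlorine atom and an isopropyl group of 3 heavy atoms, all carbon, cannot be told apart on this read-out, so this position tolerates this particular change and chloro is not needed to keep the level seen for compound 3. No measurement at hand explains why the two groups read alike.

From the compounds shown here alone, what stays open is whether that tolerance extends to groups of a different kind at the same place, such as an amine or a carboxylic acid, or to a chain longer than isopropyl. Going by these compounds, it is also open whether the same swap would leave the number unchanged on compound 1 , which gives 1100 nM and carries a different group where compound 3 has cyclopentyl, since a change that is silent on one compound need not be silent on another.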